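Permeability across side-chain variants of a shared core

This account rests on a few compounds, and the source may have more. Where it says the series, first, only, none or still open, it means among the compounds named here.

Measured so far in an ADME assay on Caco-2 cells (Homo sapiens) for permeability, read by LC-MS, in the apical to basolateral direction, with a stated time of 60 min, at pH 6.5; a lower number here means that the compound crosses the layer more slowly, a higher number that the compound crosses the layer faster:
compound 1 `Cc1cccc([C@@H](O)C(=O)N2N=CC[C@H]2C(=O)NCc2cc(Cl)ccc2-n2cnnn2)c1` gives 9.7 10^-6 cm/s
compound 2 `CC(C)CC[C@@H](O)C(=O)N1N=CC[C@H]1C(=O)NCc1cc(Cl)ccc1-n1cnnn1` gives 29 10^-6 cm/s

Compound 2 holds the higher of the two numbers in this assay , and its nearest neighbour is compound 1 , from which it is separated by a 3.0-fold higher number from compound 1 to compound 2 (0.48 log units; beyond the scatter). That one step is the whole of what is known about the side chain on the saturated chain carbon bound to a carbonyl carbon and an oxygen.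

Compound 3 `CCCC[C@@H](O)C(=O)N1N=CC[C@H]1C(=O)NCc1cc(Cl)ccc1-n1cnnn1` is the next member. It differs from compound 2 by hydrogen in place of methyl on a saturated chain carbon bound to two saturated chain carbons. Going by the values given here, no measured step exchanges one saturated chain for another; the only step at hand, from compound 1 to compound 2 , swaps a ring for a chain and is therefore only a loose guide. The chain is shortened by one carbon; the expected size of the step is small, likely within the scatter, with a slight lean towards a lower number.

For compound 3 the estimate in this assay is 22 10^-6 cm/s, ranging from 11 10^-6 cm/s to 44 10^-6 cm/s, which would mean an expected step of a 1.3-fold lower number from compound 2 to compound 3 (0.12 log units; within the scatter).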

Compound 3, apparent permeability: 9.8 10^-6 cm/s
Compound 3: middle estimate off by 2.2-fold (0.35 log units), on the high side, and the stated range ends above it.
By their numbers in this assay, from the lowest: compounds 1 and 3 (each within the scatter of the next); then compound 2.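

Within the saturated chains, hydrogen in place of methyl on a saturated chain carbon bound to two saturated chain carbons gives in this assay a 3.0-fold lower number from compound 2 to compound 3 (0.47 log units; beyond the scatter), so a change of one carbon within a chain at this position can move the number by about as much as the exchange of 3-methylphenyl for isopentyl. Butyl in place of 3-methylphenyl gives a 1.0-fold higher number from compound 1 to compound 3 (0.00 log units; within the scatter), so a saturated chain here does not by itself go with the higher number: of the three compounds only compound 2 stands apart, and compound 3 goes against any reading of chains over the ring. No measurement is at hand that would account for the gap between the isopentyl and butyl chains.

Isopentyl to butyl removes one carbon and the branch in a single change, so the compounds shown leave open which of the two goes with the step. Also open, as far as these compounds go, is how a straight pentyl chain, a longer chain such as hexyl, or an amine or a carboxylic acid on the chain would read at this position.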